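This account rests on a few compounds, and the source may have more. Where it says the series, first, only, none or still open, it means among the compounds named here.

Working notes on the series built on the core of compound 1 `Cc1cc(Nc2cc(-c3ccccc3)[nH]n2)n2nc(SCCCc3ccccc3)nc2n1`. In a functional assay on PC-9 cells (Homo sapiens) for inhibition, read by MTT assay, with a stated time of 72 h (on this read-out higher numbers stand for weaker inhibition and lower numbers for stronger inhibition), compound 1 gives 5030 nM. Compound 2 `Cc1cc(Nc2cc(-c3ccccc3)[nH]n2)n2ncnc2n1`, with hydrogen in place of (3-phenylpropyl)sulfanyl on an aromatic carbon, is reported in this assay only as a limit, > 50000 nM, and not as a number. Compound 3 `Cc1cc(Nc2cc(-c3ccccc3)[nH]n2)n2nc(SCc3cccc(Br)c3)nc2n1` gives 8900 nM in this assay. Among the numbers shown, compound 1 stands lowest of two, with compound 3 nearest; the step of a 1.8-fold higher number from compound 1 to compound 3 (0.25 log units; within the scatter) sits within the scatter, whereas an at least 9.9-fold higher number from compound 1 to compound 2 (0.99 log units; beyond the scatter) and an at least 5.6-fold lower number from compound 2 to compound 3 (0.74 log units; beyond the scatter) are both beyond it. Compound 4 `Cc1cc(Nc2cc(-c3ccccc3)[nH]n2)n2nc(SCCc3ccccc3)nc2n1` differs from compound 1 by phenyl in place of benzyl on a saturated chain carbon, two bonds along the chain from a sulfur. The measured step that bears on this is a 1.8-fold higher number from compound 1 to compound 3 (0.25 log units; within the scatter), a larger change of the same kind that stayed within the scatter, so in this assay no step beyond the scatter is expected in either direction. Compound 4 is therefore estimated at 6000 nM, with a range from 2500 nM to 15000 nM. For compound 4 the expected step is a 1.2-fold higher number from compound 1 to compound 4 (0.08 log units; within the scatter).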

Compound 4, half-maximal inhibitory concentration: 4930 nM
Compound 4: middle estimate off by 1.2-fold (0.09 log units), on the high side; the range from low to high includes it.
By their numbers in this assay, from the lowest: compounds 4, 1 and 3 (each within the scatter of the next). At a limit, above all of these: compound 2.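

In this assay, phenethylsulfanyl in place of (3-phenylpropyl)sulfanyl leaves the read-out unchanged, a 1.0-fold lower number from compound 1 to compound 4 (0.01 log units; within the scatter), and benzyl in place of 3-bromophenyl on a saturated chain carbon bound to a sulfur gives a 1.8-fold lower number from compound 3 to compound 4 (0.26 log units; within the scatter), so neither chain length nor this aryl change separates these compounds. Phenethylsulfanyl in place of hydrogen on an aromatic carbon gives an at least 10-fold lower number from compound 2 to compound 4 (1.00 log units; beyond the scatter), so the shorter chain keeps the separation from the compound without a sulfanyl group, and this step is read against a limit, not a number. Compound 2 stands only as a limit: the limit of > 50000 nM in this assay, at which 1 of the 4 values shown sits.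

The compounds shown leave open whether the phenyl ring of these chains is needed at all. A methylsulfanyl group, a chain ending in an amine or in a carboxylic acid, or a longer chain would each bear on that.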